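Swapping dimethylamino for methoxy on the benzyl group

The source may hold more compounds than are shown below. What is called first, only, known or untested is meant among the compounds shown, and "the series" means these compounds.

Measured compounds:
Compound 1 `CCN(CCCCOc1ccc(/C=C/C(=O)c2ccc(N(C)C)cc2O)cc1)Cc1ccccc1N(C)C` gives 12300 nM in an assay on isolated protein for inhibition of Amine oxidase [flavin-containing] A (Homo sapiens); a lower number here means a stronger inhibitor, a higher number a weaker inhibitor.
Compound 2 `CCN(CCCOc1ccc(C(=O)/C=C/c2ccc(N(C)C)cc2)c(O)c1)Cc1ccccc1OC` gives 26300 nM.
Compound 3 `CCN(CCCOc1ccc(C(=O)/C=C/c2ccc(N(C)C)cc2)c(O)c1)Cc1ccccc1` gives 82600 nM.

Compound 1 stands lowest of the three numbers, the strongest inhibitor shown. Compound 2 sits closest to it, and compound 3 furthest away. Compound 4 `CCN(CCCCOc1ccc(/C=C/C(=O)c2ccc(N(C)C)cc2O)cc1)Cc1ccccc1OC` keeps the whole framework of compound 1 and differs in one place: methoxy in place of dimethylamino on an aromatic carbon.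

Among the measured compounds shown here, no measured pair shows this exact swap. The nearest guide is the step of a 3.1-fold higher number from compound 2 to compound 3 (0.50 log units; beyond the scatter), which shows that removing methoxy from the same aromatic carbon of the benzyl group weakens inhibition modestly, so methoxy at that place is not neutral. Compound 1 with dimethylamino and compound 2 with methoxy differ elsewhere as well, so their gap cannot be attributed to the benzyl substituent alone. The expectation for compound 4 is therefore a small step, plausibly a slightly higher number than compound 1, within or just beyond the scatter: a 1.5-fold higher number from compound 1 to compound 4 (0.17 log units; within the scatter). Compound 4 is thus estimated at 18000 nM, with a range from 7000 nM to 45000 nM.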

Compound 4, half-maximal inhibitory concentration: 9200 nM
Compound 4: middle estimate off by 2.0-fold (0.29 log units), on the high side; the measured number falls inside the stated range.
By their numbers in this assay, from the lowest: compounds 4 and 1 (each within the scatter of the next); then compound 2; then compound 3.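

In this assay, exchanging dimethylamino for methoxy on this aromatic carbon, ortho to a large group, gives a 1.3-fold lower number from compound 1 to compound 4 (0.13 log units; within the scatter) and so stays within the scatter. On the framework of compound 1, the two groups therefore cannot be told apart at this place, although they differ in their heavy atoms, which is something the earlier step on the other framework, with hydrogen and methoxy, could not show. Nothing measured here explains why the two groups read alike.

As far as these compounds go, it remains open whether hydrogen at this carbon would weaken inhibition on the framework of compound 1 as it does in a 3.1-fold higher number from compound 2 to compound 3 (0.50 log units; beyond the scatter). From the compounds shown here alone, whether hydroxyl, ethoxy or a chlorine atom would fit here as well as methoxy and dimethylamino also remains open.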